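The source may hold more compounds than are shown below. What is called first, only, known or untested is meant among the compounds shown, and "the series" means these compounds.

The series rests on a shared core, seen in compound 1 `COc1cc(C(=O)c2cn(-c3cccc([N+](=O)[O-])c3)cc2-c2ccccc2)cc(OC)c1OC` and compound 2 `COc1cc(C(=O)c2cn(-c3ccccc3)cc2-c2cccc(Cl)c2)cc(OC)c1OC`. In a functional assay on MCF7 cells (Homo sapiens) for cytotoxicity, read by MTT assay, with a stated time of 96 h (on this read-out lower numbers stand for stronger inhibition and higher numbers for weaker inhibition), compound 1 gives 550 nM. For the measured compounds named here, in the same this assay compound 2 gives 540 nM, the lowest of the two numbers so far, though compound 1 sits so close to it that the two values fall within the scatter of repeated measurements and cannot be told apart.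

Compound 3 `COc1cc(C(=O)c2cn(-c3ccccc3)cc2-c2cc(F)ccc2F)cc(OC)c1OC` is not yet measured. Compared with compound 2 it carries 2,5-difluorophenyl in place of 3-chlorophenyl on an aromatic carbon. Going by the values given here, no pair of measured compounds shows the effect of such an exchange, so the size of the step from compound 2 to compound 3 in this assay cannot be read from the data. The author expects a step no larger than the scatter, with no firm direction, so that a 1.5-fold higher number from compound 2 to compound 3 (0.17 log units; within the scatter) is the estimated step. Compound 3 is accordingly expected to give about 800 nM, within a range from 250 nM to 2500 nM.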

Compound 3, half-maximal inhibitory concentration: 230 nM
Compound 3: middle estimate off by 3.5-fold (0.54 log units), on the high side, and the stated range ends above it.
By their numbers in this assay, from the lowest: compound 3; then compounds 2 and 1 (each within the scatter of the next).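

In this assay the exchange of 3-chlorophenyl for 2,5-difluorophenyl brings a 2.3-fold lower number from compound 2 to compound 3 (0.37 log units; beyond the scatter) and gives the series its first step beyond the scatter, so the group on this aromatic carbon, two ring bonds from the ring nitrogen, does bear on the number. Both groups hold one six-membered aromatic ring of carbon only, with no hydrogen-bond donors or acceptors and no net charge, so the exchange lies in the chlorine and fluorine atoms and in where they sit on that ring. No measurement shown here accounts for the step.

From the compounds shown here alone, whether the lower number needs both fluorines or would follow from one alone stays open. So does how this position would respond to a phenyl ring carrying a methoxy group or an amine.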